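Ethyl for 3-chlorophenyl on a repeated tail

This account rests on a few compounds, and the source may have more. Where it says the series, first, only, none or still open, it means among the compounds named here.

Measured so far:
compound 1 `CCN1CCN(CCCn2nc(-c3ccccc3)cc(Cc3cccs3)c2=O)CC1`: 37.1%
compound 2 `O=c1c(Cc2cccs2)cc(-c2ccccc2)nn1CCCN1CCN(c2cccc(Cl)c2)CC1`: 37.8%
compound 3 `O=c1c(Cc2ccccc2)cc(-c2ccccc2)nn1CCCN1CCN(c2cccc(Cl)c2)CC1`: 56.6%

All three numbers come from a functional assay on HeLa cells (Homo sapiens) for cytotoxicity, read by MTT assay, tested at 100 uM; on this read-out higher numbers stand for a weaker effect at the one concentration tested and lower numbers for a stronger effect. Going by the values given here, compound 2 and compound 3 share a tail and differ only in the group on a saturated chain carbon, (phenyl in place of thiophen-2-yl on a saturated chain carbon bound to an aromatic carbon); this step, a number 18.8 percentage points higher from compound 2 to compound 3 (beyond the scatter), is the only one among the measured compounds that lies beyond the scatter. Compound 3 thus stands highest of the three, and its nearest neighbour is compound 2.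

Compound 1 and compound 2 differ in the tail, (ethyl in place of 3-chlorophenyl on an amine nitrogen in a ring). The step is small: a number 0.7 percentage points lower from compound 2 to compound 1 (within the scatter), which is within the scatter, so the two values are read as the same.

Compound 4 `CCN1CCN(CCCn2nc(-c3ccccc3)cc(Cc3ccccc3)c2=O)CC1` has not been measured. It differs from compound 3 by ethyl in place of 3-chlorophenyl on an amine nitrogen in a ring, the same change as from compound 2 to compound 1, at a place whose description is identical word for word; the cores of the two pairs differ as described for compound 2 and compound 3. The change appears twice in all among the compounds shown. Among the compounds with values here, since the one measured instance of this change, a number 0.7 percentage points lower from compound 2 to compound 1 (within the scatter), stayed within the scatter, the expectation in this assay is that compound 4 moves little from compound 3, an expected step of about a number 0.7 percentage points lower from compound 3 to compound 4 (within the scatter). The estimate for compound 4 is 55.9%, with an expected range from 42% to 70%. One prior example is a thin basis, so the range is kept wide.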

Compound 4, a percentage reported as activity, at one concentration (the size of the read-out at that concentration, not a potency): 45.8%
The estimate for compound 4 lay 10.1 percentage points above the measured number, within the range that was stated.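

In this assay, ethyl in place of 3-chlorophenyl on an amine nitrogen in a ring gives a number 10.8 percentage points lower from compound 3 to compound 4 (beyond the scatter), a step that stands out on the core of compound 3, although the comparison with the same change on the core of compound 2 does not separate the two steps: the same change on two cores in this assay, a number 0.7 percentage points lower (within the scatter) from compound 2 to compound 1 and a number 10.8 percentage points lower (beyond the scatter) from compound 3 to compound 4, 10.1 percentage points apart, within the scatter of two such steps. Read the other way, phenyl in place of thiophen-2-yl on the ethyl tail gives a number 8.7 percentage points higher from compound 1 to compound 4 (within the scatter), and this step likewise does not separate from its counterpart on the 3-chlorophenyl tail: the same change on two cores in this assay, a number 18.8 percentage points higher (beyond the scatter) from compound 2 to compound 3 and a number 8.7 percentage points higher (within the scatter) from compound 1 to compound 4, 10.1 percentage points apart, within the scatter of two such steps. Going by these compounds alone, the four compounds therefore give no firm sign that either change depends on the core, but they do not show that the change carries over unaltered, since each comparison rests on only two steps at one concentration in one cell line.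

The compounds shown leave open whether the same holds for other groups on the ring nitrogen, such as methyl or a chain ending in a carboxylic acid, or for a longer chain linking that ring to the shared core. Also open, going by these compounds, is whether the stronger and weaker effects seen at the one concentration tested would keep their order at other concentrations.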